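A few compounds are considered here, and "the series" means these few. Any claim that something is new, unique, unknown or untested is made for them only; others in the source may bear on it.

Two compounds of this series have so far been run in a functional assay on DU-145 cells (Homo sapiens) for inhibition, read by sulforhodamine B assay, with a stated time of 48 h; on this read-out higher numbers stand for weaker inhibition of growth and lower numbers for stronger inhibition of growth. Compound 1 `O=C(Nc1cccc(-n2cc(-c3ccncc3)c(-c3ccc(Cl)c(O)c3)n2)c1)Nc1cccc(C(F)(F)F)c1` reaches only the assay limit, > 32500 nM. Compound 1 thus sits at the limit of > 32500 nM in this assay, at which 1 of the 2 values shown sits. Among the measured compounds shown here, compound 2 `COc1cc(-c2nn(-c3cccc(NC(=O)c4cccc(C(F)(F)F)c4)c3)cc2-c2ccncc2)ccc1Cl` gives 32100 nM, the only number in hand. Compound 3 `COc1cc(-c2nn(-c3cccc(NC(=O)c4ccc(Cl)c(C(F)(F)F)c4)c3)cc2-c2ccncc2)ccc1Cl` differs from compound 2 by chloro in place of hydrogen on an aromatic carbon, a chloro in place of hydrogen on an aromatic carbon. For the measured compounds named here, no step between measured compounds is available, so no reference for the size of such a change exists. The expected shift is a 1.3-fold lower number from compound 2 to compound 3 (0.11 log units; within the scatter), none beyond the scatter, with a fair chance that only a limit is returned. Compound 3 is estimated at 25000 nM, between 8000 nM and 40000 nM.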

Compound 3, concentration for total growth inhibition: > 32500 nM
Compound 3 gave a limit, no number; the forecaster's own chance of this, stated with the estimate: 50%; middle value at least 1.3-fold (0.11 log units) from the limit.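

In this assay, chloro on the aromatic carbon ortho to the trifluoromethyl group gives an at least 1.0-fold higher number from compound 2 to compound 3 (0.00 log units; that floor lies within the scatter), the first step readable in the series, and no gain in growth inhibition appears at this position. That step is only a floor: compound 3 returns a limit, not a number. Values at the limit now make up most of the set: the limit of > 32500 nM in this assay, at which 2 of the 3 values shown sit.

On these data alone, how far compound 3 actually lies from compound 2 remains open. Also open, as far as these compounds go, is whether fluoro or an amine on this same carbon would give a number rather than a limit.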